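Adding a sulfonamide chain to compound 2

A few compounds are considered here, and "the series" means these few. Any claim that something is new, unique, unknown or untested is made for them only; others in the source may bear on it.

Measured in a physicochemical assay for lipophilicity, read by HPLC, at pH 7.5; a higher number here means a more lipophilic compound, a lower number a more polar compound:
- compound 1 `CCOc1ccccc1-c1ccc(-c2nc3cnccc3c(N[C@H](CC)C(=O)NS(=O)(=O)C3CC3)c2C#N)cc1` gives 2.3
- compound 2 `CCOc1ccccc1-c1ccc(-c2nc3cnccc3c(N)c2C#N)cc1` gives 3
- compound 3 `CC[C@@H](Nc1c(C#N)c(-c2ccc(-c3ccc(Cl)cc3)cc2)nc2cnccc12)C(N)=O` gives 3.1

Compound 2 gives 3 in this assay. This lies within the usual scatter of compound 3 at 3.1, while the gap down to compound 1 at 2.3 lies beyond the scatter.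

The next compound is compound 4 `CCOc1ccccc1-c1ccc(-c2nc3cnccc3c(NC(CC)CNS(=O)(=O)C3CC3)c2C#N)cc1`, which departs from compound 2 by a group of 11 heavy atoms (7 carbon, 1 nitrogen, 2 oxygen, 1 sulfur; one three-membered non-aromatic ring of carbon only) in place of a hydrogen atom, on a nitrogen on an aromatic ring. In words, a group of 11 heavy atoms (7 carbon, 1 nitrogen, 2 oxygen, 1 sulfur; one three-membered non-aromatic ring of carbon only) takes the place of a hydrogen atom, on a nitrogen on an aromatic ring.

Going by the values given here, only one measured step bears on this change: a number 0.70 log units higher from compound 1 to compound 2 (beyond the scatter). Read in reverse, it would suggest a lower number for compound 4. However, the group in compound 4 has no carbonyl where the group in compound 1 has one, and no measured step covers that difference. The direction is therefore uncertain, and the range must stay wide.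

On balance, a modest rise is expected, with an estimated a number 0.50 log units higher from compound 2 to compound 4 (beyond the scatter). Compound 4 is estimated at 3.5, with an expected range from 2.8 to 4.2.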

Compound 4, distribution coefficient: 3.6
For compound 4 the middle estimate is 0.10 log units below the measured one; low and high end bracket the measured number.
By their numbers in this assay, from the lowest: compound 1; then compounds 2 and 3 (each within the scatter of the next); then compound 4.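

Compound 1 had shown this position only with a chain that lowers the number, and compound 4 shows that a chain on this nitrogen can also raise it. In this assay the reading is a number 0.60 log units higher from compound 2 to compound 4 (beyond the scatter) and so runs against the earlier step, a number 0.70 log units higher from compound 1 to compound 2 (beyond the scatter), which means that replacing the hydrogen atom with a cyclopropyl-bearing sulfonamide chain does not in itself fix the direction of change. The two chains differ by the carbonyl that compound 1 has and compound 4 lacks, and this one difference comes with the largest step among these compounds, a number 1.30 log units higher from compound 1 to compound 4 (beyond the scatter). Nothing shown here accounts for this reversal.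

Still open, from the compounds shown here alone, is whether the carbonyl would have the same effect on the number with a longer chain or with a methyl group in place of the cyclopropyl ring on the sulfonyl. Also open, going by these compounds, is how a carboxylic acid or an amine at the end of the chain would read in this assay, since the two chains compared here both end in a sulfonamide.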